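The source may hold more compounds than are shown below. What is called first, only, known or untested is meant among the compounds shown, and "the series" means these compounds.

Compound 1 `CCN(CC)C(=O)c1nc2ccccc2n1Cc1ccccc1`: in an assay on membranes from HEK293 cells for displacement of a labelled ligand from Translocator protein (Homo sapiens), read by scintillation counting, with a stated time of 90 min (on this read-out higher numbers stand for weaker inhibition and lower numbers for stronger inhibition), compound 1 gives > 10000 nM, which is a limit of the assay.
Compound 2 `CCN(CC)C(=O)c1cc2cc(C)ccc2n1Cc1ccc(OCc2ccccc2)cc1`: in this assay compound 2 gives > 10000 nM, again a limit rather than a number.

Compound 2 therefore stands at the limit of > 10000 nM in this assay, at which 2 of the 2 values shown sit, and no firmer figure for it is available. Compound 3 `CCN(CC)C(=O)c1cc2cc(C)ccc2n1Cc1ccc(O)cc1` differs from compound 2 by hydrogen in place of benzyl on an oxygen on an aromatic ring, so a benzyloxy group becomes a hydroxy group. Among the compounds with values here, no measured pair shows what such a change does here, so no direction can be read from the data. The step from compound 2 to compound 3 is expected to be a number no higher from compound 2 to compound 3 (the limit leaves the size open), nothing beyond the scatter. Compound 3 is estimated at 10000 nM, with a range from 2000 nM to 50000 nM.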

Compound 3, inhibition constant: > 10000 nM
Compound 3: no number, only a limit (the forecaster's own chance of this, stated with the estimate: 60%); the middle value sits exactly at the limit.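

No step from compound 2 to compound 3 can be read, since each gives only a limit in this assay: the limit of > 10000 nM in this assay, at which 3 of the 3 values shown sit.

The compounds shown leave open how strongly any of them inhibits and whether replacing benzyloxy with hydroxy changes that.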